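This account rests on a few compounds, and the source may have more. Where it says the series, first, only, none or still open, it means among the compounds named here.

Working notes on the series, read in a functional assay on MCF7 cells (Homo sapiens) for antiproliferative activity; a higher number here means a weaker inhibitor, a lower number a stronger inhibitor. Compound 1 `COc1ccc(C(=O)Nc2cc3ccc(OC4CCN(C)CC4)c(C)c3oc2=O)cc1CC=C(C)C` gives 1580 nM, compound 2 `C#CCOc1ccc(C(=O)Nc2cc3ccc(OC4CCN(C)CC4)c(C)c3oc2=O)cc1CC=C(C)C` gives 1120 nM and compound 3 `Cc1c(OC2CCN(C)CC2)ccc2cc(NC(=O)c3ccc(O)c(CCC(C)C)c3)c(=O)oc12` gives 1250 nM. The value of compound 3 lies within the scatter of both others, so it cannot be separated from either.

The next compound is compound 4 `C=CCc1cc(C(=O)Nc2cc3ccc(OC4CCN(C)CC4)c(C)c3oc2=O)ccc1O`, and the change from compound 3 is vinyl in place of isobutyl on a saturated chain carbon bound to an aromatic carbon. In words, this is vinyl in place of isobutyl on a saturated chain carbon bound to an aromatic carbon, which reads as isopentyl to allyl when cut one bond further out.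

Among the measured compounds shown here, no measured step covers this change. For the measured compounds named here, the only step available, a 1.4-fold lower number from compound 1 to compound 2 (0.15 log units; within the scatter), is ethynyl in place of hydrogen on a saturated chain carbon bound to an oxygen on an aromatic ring, which is a different place. Taking compound 3 at 1250 nM as the reference, no step beyond the scatter is expected in this assay.

The expected step is a 1.2-fold higher number from compound 3 to compound 4 (0.08 log units; within the scatter). For compound 4 the estimated value is 1500 nM, with an expected range of 700 nM to 3200 nM.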

Compound 4, half-maximal inhibitory concentration: 2170 nM
Beside the measured number, compound 4's estimate is 1.4-fold (0.16 log units) below it, within the range that was stated.
By their numbers in this assay, from the lowest: compounds 2, 3, 1 and 4 (each within the scatter of the next).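

In this assay the step to the shorter unsaturated group is a 1.7-fold higher number from compound 3 to compound 4 (0.24 log units; within the scatter), so vinyl in place of isobutyl on a saturated chain carbon bound to an aromatic carbon, or isopentyl to allyl when cut one bond further out, gives no separable difference. Among the compounds shown here, this is the first measured change at this place, and it shows that losing part of the chain and bringing in a double bond together leave the number within the scatter. No measured property of these groups is available to bear on this result.

From the compounds shown here alone, whether any group at this place can move the number beyond the scatter stays open. A carboxylic acid, a primary amine or a chain longer than isobutyl on the same saturated chain carbon would test this more widely than the two hydrocarbon groups compared here.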